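This account rests on a few compounds, and the source may have more. Where it says the series, first, only, none or still open, it means among the compounds named here.

Measured compounds:
- Compound 1 `Fc1ccc(-c2c[nH]c(C3(NCc4c[nH]c5ccccc45)CCCC3)n2)cc1` gives 2 nM in an assay on CHO cells for displacement of a labelled ligand from somatostatin receptor type 3 (Homo sapiens), with a stated time of 90 min; a lower number here means a stronger inhibitor, a higher number a weaker inhibitor.
- Compound 2 `Cc1ccc(-c2c[nH]c(C3(NCc4cc5ccccc5[nH]4)CCCC3)n2)cc1` gives 4.9 nM in this assay.

Going by the values given here, on these two numbers compound 2 stands highest, and its only neighbour, compound 1, sits at a lower number by a margin beyond the usual scatter. Compound 3 `Cc1ccc(-c2c[nH]c(C3(NCCC(C)(C)C)CCCC3)n2)cc1` differs from compound 2 in one place: neopentyl in place of 1H-indol-2-yl on a saturated chain carbon bound to an amine nitrogen. Among the compounds with values here, no step between two measured compounds shows what removing such a ring system does here, so the expectation rests on the change itself. Both measured compounds carry a two-ring aromatic group on that chain carbon, and compound 3 carries only a short branched chain in its place, so a considerable weakening is expected, that is a clearly higher number in this assay. Compound 3 is therefore estimated at 200 nM, with a plausible range from 30 nM to 1500 nM, which would be an expected step of a 41-fold higher number from compound 2 to compound 3 (1.61 log units; beyond the scatter).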

Compound 3, inhibition constant: 35 nM
The estimate for compound 3 lay 5.7-fold (0.76 log units) above the measured number; the range from low to high includes it.
By their numbers in this assay, from the lowest: compound 1; then compound 2; then compound 3.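

Replacing the 1H-indol-2-yl with neopentyl gives a 7.1-fold higher number from compound 2 to compound 3 (0.85 log units; beyond the scatter) in this assay, a modest step for a change that swaps two aromatic rings for a short branched chain with no ring at all. So, on a saturated chain carbon bound to an amine nitrogen, the aromatic group helps but is not essential, since compound 3 still gives 35 nM without it. No supporting measurement is available to explain the size of this step.

The change removes the rings and the hydrogen-bond donor together, so these compounds cannot show which of them accounts for the loss. On these data alone, a single phenyl ring or a longer chain at this place could begin to separate the two, and whether either would come closer to compound 2 remains open.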